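The compounds below may be only part of what the source reports. "The series", "measured", "known", "first", "only" and "open" are said of these compounds alone.

Compound 1 `COc1ccc(/C=C/c2ccc3ccccc3c2)cc1F`: > 5000 nM
Compound 2 `COc1cc(/C=C\c2ccc3ccccc3c2)ccc1F`: 450 nM
Compound 3 `CN(C)c1ccc(/C=C\c2ccc3ccccc3c2)cc1`: 3660 nM

All three compounds were tested in a functional assay on HT-29 cells (Homo sapiens) for inhibition; on this read-out higher numbers stand for weaker inhibition and lower numbers for stronger inhibition. Compound 1 gives > 5000 nM, which is a limit of the assay and not a number. Compound 2 reads 450 nM, and compound 3 reads 3660 nM.

Compound 4 `CCN(CC)c1cc(/C=C/c2ccc3ccccc3c2)ccc1OC` has not yet been measured. It departs from compound 1 through diethylamino in place of fluoro on an aromatic carbon, ortho to a methoxy group. Among the measured compounds shown here, no measured step shows what such a change does, so the expectation is modest: no step beyond the scatter in this assay, with compound 4 remaining weak and possibly returning only a limit. That expectation starts from compound 1, which sits at the limit of > 5000 nM in this assay, at which 1 of the 3 values shown sits. The expected change is a step that the limit leaves unreadable from compound 1 to compound 4. Compound 4 is expected at about 6000 nM, within an estimated range of 2000 nM to 20000 nM.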

Compound 4, half-maximal inhibitory concentration: > 5000 nM
Compound 4: a limit, no number; the forecaster's own chance of this, stated with the estimate: 60%; the middle value is on the limit's open side.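

In this assay, compound 1 and compound 4 each return only a limit and not a number, so no step can be read between them: the limit of > 5000 nM in this assay, at which 2 of the 4 values shown sit. The compounds shown leave open what diethylamino in place of fluoro on an aromatic carbon does in this assay.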